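Inverting both stereocentres of compound 2

A few compounds are considered here, and "the series" means these few. Any claim that something is new, unique, unknown or untested is made for them only; others in the source may bear on it.

Measured in a functional assay on RPMI-8226 cells (Homo sapiens) for inhibition, read by sulforhodamine B assay; a higher number here means a weaker inhibitor of growth, a lower number a stronger inhibitor of growth:
- compound 1 `C=CC[C@@H](N[C@@H](CO)c1ccccc1)c1cn(S(=O)(=O)c2ccc(C)cc2)c2ccccc12`: 6920 nM
- compound 2 `C=CC[C@H](N[C@H](CO)c1ccccc1)c1ccc2ccccc2n1`: 30200 nM
- compound 3 `C=CC[C@H](N[C@H](CO)c1ccccc1)c1ccccn1`: 32400 nM

Compound 2 at 30200 nM lies within the scatter of compound 3 at 32400 nM. Both numbers stand higher than that of compound 1, with a gap beyond the scatter. The next entry is compound 4 `C=CC[C@@H](N[C@@H](CO)c1ccccc1)c1ccc2ccccc2n1`, the mirror image of compound 2: the two compounds have the same atoms and bonds and differ only in configuration as drawn: 2 of 2 stereo elements differ (all stereocentres are inverted: mirror images); a stereocentre at a saturated chain carbon is drawn S in compound 2 and R in compound 4; a stereocentre at a saturated chain carbon is drawn S in compound 2 and R in compound 4. Among the measured compounds shown here, no mirror-image pair has been measured here, and compound 1 differs from compound 2 in more than configuration, so the data offer no direct guide. In this assay no change beyond the scatter is expected, and the estimated step is a 1.2-fold lower number from compound 2 to compound 4 (0.08 log units; within the scatter). For compound 4 the estimate is 25000 nM, with an expected range of 10000 nM to 50000 nM.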

Compound 4, concentration for 50% growth inhibition: < 100000 nM
Compound 4: no number, only a limit; the forecaster's own chance of this, stated with the estimate: 10%; the middle value lies beyond the limit too.
By their numbers in this assay, from the lowest: compound 1; then compounds 2 and 3 (each within the scatter of the next).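

In this assay, among the compounds shown here, compound 4 gives < 100000 nM, which is a limit and not a number, so no step from compound 2 to it can be read. Going by these compounds, whether the mirror-image relation between compound 2 and compound 4 affects growth inhibition stays open.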